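From allyloxycarbonyl to ethoxycarbonyl on a shared core

This account rests on a few compounds, and the source may have more. Where it says the series, first, only, none or still open, it means among the compounds named here.

Measured in a functional assay on BXPC-3 cells (Homo sapiens) for antiproliferative activity, read by sulforhodamine B assay, with a stated time of 72 h; on this read-out lower numbers stand for stronger inhibition and higher numbers for weaker inhibition:
- Compound 1 `CCCSc1ccc2c3c(cccc13)C1=NC(=O)C(C(=O)OCC)=C12`: 5800 nM
- Compound 2 `C=CCSc1ccc2c3c(cccc13)C1=NC(=O)C(C(=O)OCC(=O)SCCC)=C12`: 13700 nM
- Compound 3 `C=CCOC(=O)C1=C2C(=NC1=O)c1cccc3c(SCC=C)ccc2c13`: 2500 nM

Compound 3 has the lowest of the three numbers in this assay, and compounds 1 and 2 both lie above it by more than the scatter. Compound 4 `C=CCSc1ccc2c3c(cccc13)C1=NC(=O)C(C(=O)OCC)=C12` has not yet been measured. Its difference from compound 3 is methyl in place of vinyl on a saturated chain carbon bound to an oxygen next to a carbonyl group. In words, it has methyl in place of vinyl on a saturated chain carbon bound to an oxygen next to a carbonyl group, so allyloxycarbonyl becomes ethoxycarbonyl.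

Going by the values given here, one measured step bears on this place: a 5.5-fold lower number from compound 2 to compound 3 (0.74 log units; beyond the scatter). That step is modest and involves a different exchange, so it gives no direct size for this one. Compound 1 also carries ethoxycarbonyl and gives 5800 nM, but it differs from compound 4 elsewhere, which makes it only a loose guide. A small rise in the number is therefore expected, near the edge of the scatter. The expected step is a 1.5-fold higher number from compound 3 to compound 4 (0.18 log units; within the scatter). For compound 4 the estimated value is 3800 nM, with an expected range of 1700 nM to 8000 nM.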

Compound 4, half-maximal inhibitory concentration: 2500 nM
Beside the measured number, compound 4's estimate is 1.5-fold (0.18 log units) above it; measured number inside the range.
By their numbers in this assay, from the lowest: compounds 3 and 4 (each within the scatter of the next); then compound 1; then compound 2.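

In this assay, the exchange of allyloxycarbonyl for ethoxycarbonyl gives no change at the digits printed from compound 3 to compound 4 (within the scatter), so methyl and vinyl cannot be told apart on this saturated chain carbon bound to an oxygen next to a carbonyl group. With methyl in place of (propylsulfanyl)carbonyl on that same carbon, the comparison gives a 5.5-fold lower number from compound 2 to compound 4 (0.74 log units; beyond the scatter), which matches the step already seen with vinyl and sets compound 2 apart from both shorter groups. The new compound also opens a comparison at the other chain, where vinyl in place of ethyl on a saturated chain carbon bound to a sulfur gives a 2.3-fold lower number from compound 1 to compound 4 (0.37 log units; beyond the scatter), so among these compounds a change on the sulfur chain moves the number beyond the scatter while the change from vinyl to methyl on the oxygen chain does not.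

No evidence is available to explain these differences. Still open, on these data alone, is how a longer chain, an amine or a carboxylic acid on the oxygen chain would read, and whether the sulfur-chain step would hold with allyloxycarbonyl in place of ethoxycarbonyl.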